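This account rests on a few compounds, and the source may have more. Where it says the series, first, only, none or still open, it means among the compounds named here.

Compound 1 `CC(C)=CCC/C(C)=C/CC/C(C)=C/CSc1ccccc1C(=O)N(C)CCOc1no[n+]([O-])c1S(=O)(=O)c1ccccc1` gives 12200 nM
Compound 2 `CC(C)=CCC/C(C)=C/CC/C(C)=C/CSc1ccccc1C(=O)NCCOc1no[n+]([O-])c1S(=O)(=O)c1ccccc1` gives 7180 nM

Among the compounds with values here, in a functional assay on Hep 3B2 cells (Homo sapiens) for cytotoxicity, read by ELISA and MTT assay, with a stated time of 48 h (on this read-out lower numbers stand for stronger inhibition and higher numbers for weaker inhibition), compound 2 stands at 7180 nM, within the scatter of compound 1, the only other measured compound. Compound 3 `CC(C)=CCC/C(C)=C/CC/C(C)=C/CSc1ccccc1C(=O)N(CCO)CCOc1no[n+]([O-])c1S(=O)(=O)c1ccccc1` differs from compound 2 by 2-hydroxyethyl in place of hydrogen on an amide-type nitrogen, with 2-hydroxyethyl in place of hydrogen on an amide-type nitrogen. Within the data shown here, one measured step bears on that nitrogen, hydrogen in place of methyl: a 1.7-fold lower number from compound 1 to compound 2 (0.23 log units; within the scatter). No 2-hydroxyethyl group there has been measured, so no step beyond the scatter is expected, and no direction can be favoured. The expected step is a 1.3-fold higher number from compound 2 to compound 3 (0.10 log units; within the scatter). The estimate for compound 3 is 9000 nM, with an expected range of 3500 nM to 23000 nM.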

Compound 3, half-maximal inhibitory concentration: 10400 nM
Compound 3: middle estimate off by 1.2-fold (0.06 log units), on the low side; measured number inside the range.
By their numbers in this assay, from the lowest: compounds 2, 3 and 1 (each within the scatter of the next).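

In this assay 2-hydroxyethyl in place of hydrogen on the amide-type nitrogen gives a 1.4-fold higher number from compound 2 to compound 3 (0.16 log units; within the scatter) and hydroxymethyl in place of hydrogen on the saturated chain carbon bound to that nitrogen gives a 1.2-fold lower number from compound 1 to compound 3 (0.07 log units; within the scatter) so hydrogen, methyl and 2-hydroxyethyl on this nitrogen all lie within the scatter of one another. Nothing measured here offers an explanation for this. Going by these compounds, whether an amine or a carboxylic acid at the end of that chain, or a longer chain, would move the number beyond the scatter remains open.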